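The compounds below may be only part of what the source reports. "The series", "measured", "known", "first", "only" and "open" are said of these compounds alone.

Measured in a physicochemical assay for lipophilicity; a higher number here means a more lipophilic compound, a lower number a more polar compound:
- compound 1 `Cc1nc(C)c(COC(=O)COc2ccc(-c3cc(=O)c4c(O)c(O)c(O)cc4o3)cc2)nc1C`: 2.39
- compound 2 `Cc1nc(C)c(C(=O)N[C@@H](C(=O)Oc2ccc(-c3cc(=O)c4c(O)c(O)c(O)cc4o3)cc2)C(C)C)nc1C`: 1.38
- compound 3 `Cc1nc(C)c(COC(=O)N[C@@H](C(=O)Oc2ccc(-c3cc(=O)c4c(O)c(O)c(O)cc4o3)cc2)C(C)C)nc1C`: 1.04

Compound 3 has the lowest of these numbers, beyond the scatter from both others. Compound 4 `CC[C@H](C)[C@@H](NC(=O)OCc1nc(C)c(C)nc1C)C(=O)Oc1ccc(-c2cc(=O)c3c(O)c(O)c(O)cc3o2)cc1` differs from it by methyl in place of hydrogen on a saturated chain carbon, three bonds along the chain from an amide-type nitrogen and a carbonyl carbon. Among the measured compounds shown here, the only measured step, a number 0.34 log units lower from compound 2 to compound 3 (beyond the scatter), is a different change, so it offers only a loose guide to size. For the measured compounds named here, no measured step covers this change. A modest rise in this assay is expected, and the estimated step is a number 0.36 log units higher from compound 3 to compound 4 (beyond the scatter). For compound 4 the expected value is 1.4, with an estimated range of 1.05 to 1.8.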

Compound 4, partition coefficient: 2.83
Estimate against measurement, compound 4: 1.43 log units below; the measured number lies above the stated range.
By their numbers in this assay, from the lowest: compound 3; then compound 2; then compound 1; then compound 4.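

In this assay the change from isopropyl to sec-butyl gives a number 1.79 log units higher from compound 3 to compound 4 (beyond the scatter) as a large step for a single added carbon. Among the compounds shown here, compound 2 and compound 3 both carry isopropyl, so only this pair reads the saturated chain carbon, and it shows the number there responding strongly to one methyl. Nothing available accounts for a step of this size.

Open, as far as these compounds go, is whether the rise continues with a longer chain or a phenyl group at this carbon. Also open, from the compounds shown here alone, is whether sec-butyl gives a similar step when the carbamate is replaced by the amide of compound 2.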